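Thiocarbonyl substituent swap on the shared core of compound 2

This account rests on a few compounds, and the source may have more. Where it says the series, first, only, none or still open, it means among the compounds named here.

Of the compounds shown here, three have been measured in a functional assay on HeLa cells (Homo sapiens) for cytotoxicity, read by MTT assay, with a stated time of 72 h, tested at 10 uM; on this read-out lower numbers stand for less inhibition of growth and higher numbers for more inhibition of growth at the one concentration tested. Compound 1 `Cc1cccc(/C(N)=N/NC(=S)N2CCSCC2)n1` gives 67.6%, compound 2 `N/C(=N\NC(=S)N1CCSCC1)c1ccccn1` gives 54.5%, and compound 3 `N/C(=N\NC(=S)N1CCSCC1)c1ccc(F)cn1` gives 70.5%. Compound 2 stands lowest of the three: one step is a number 13.1 percentage points lower from compound 1 to compound 2 (beyond the scatter), and the other step is a number 16 percentage points higher from compound 2 to compound 3 (beyond the scatter). Both of these steps alter the aromatic ring of the shared core; the step from compound 1 to compound 2 is hydrogen in place of methyl on an aromatic carbon, and the step from compound 2 to compound 3 is fluoro in place of hydrogen on an aromatic carbon.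

Compound 4 `N/C(=N\NC(=S)N1CCCC1)c1ccccn1` is not yet measured. It differs from compound 2 at a different site, namely (pyrrolidin-1-yl in place of thiomorpholin-4-yl on a thiocarbonyl carbon). For the measured compounds named here, no measured step touches the thiocarbonyl substituent, so neither step gives a direction for this change. The two aromatic-ring steps show that single-group changes in this series move this assay by modest amounts in either direction.

The expectation for compound 4 in this assay is therefore a number close to compound 2, with a wide range: compound 4 is estimated at 55%, between 35% and 75%. The estimated step from compound 2 to compound 4 is a number 0.5 percentage points higher from compound 2 to compound 4 (within the scatter), which would lie within the scatter.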

Compound 4, percent growth inhibition at one concentration: 63.5%
The estimate for compound 4 lay 8.5 percentage points below the measured number, and the stated range covers the measured number.
By their numbers in this assay, from the lowest: compounds 2, 4, 1 and 3 (each within the scatter of the next, the first and the last beyond it).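

For the compounds shown here, this is the first reading at the thiocarbonyl substituent: in this assay, pyrrolidin-1-yl in place of thiomorpholin-4-yl on a thiocarbonyl carbon gives a number 9 percentage points higher from compound 2 to compound 4 (within the scatter) and so cannot be told apart from repeat variation. On this pair, the six-membered ring with its ring sulfur can give way to the five-membered ring with no ring sulfur while growth inhibition at the one concentration tested stays in the same band, so this site accepts a sizeable exchange of ring without a clear effect, whereas both single-group steps on the aromatic ring of the shared core lay beyond the scatter. Nothing available explains this tolerance or tests it further.

Still open, as far as these compounds go, is whether piperidin-1-yl, morpholin-4-yl or an open-chain dimethylamino group on the thiocarbonyl carbon would stay in that band, which would show how far the tolerance extends beyond this one pair. Also open, from the compounds shown here alone, is whether pyrrolidin-1-yl combined with the methyl or fluoro group on the aromatic ring behaves as the separate steps would suggest, and whether any of these readings holds across a range of concentrations.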